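Bromo in place of iodo: compound 2 to compound 4

The source may hold more compounds than are shown below. What is called first, only, known or untested is meant among the compounds shown, and "the series" means these compounds.

Three compounds on a shared core have been run in a functional assay on MCF7 cells (Breast, Homo sapiens) for inhibition; a higher number here means a weaker inhibitor of growth, a lower number a stronger inhibitor of growth. Compound 1 `Cc1cc(-c2nc3cc(F)c(F)cc3s2)ccc1N` gives < 10 nM in this assay, and that figure is a limit of the assay rather than a number. Compound 2 `Nc1ccc(-c2nc3cc(F)ccc3s2)cc1I` likewise gives < 10 nM in this assay, again a limit. Compound 3 `Nc1ccc(-c2nc3ccc(F)cc3s2)cc1Cl` returns < 10 nM in this assay, also a limit. Compound 2 therefore stands exactly where every value shown stands, namely at the limit of < 10 nM in this assay, at which 3 of the 3 values shown sit. No two of these compounds differ in a single place, so no measured step exists within the set, and nothing separates compound 2 from compound 1 or compound 3 beyond their common limit.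

Compound 4 `Nc1ccc(-c2nc3cc(F)ccc3s2)cc1Br` is the next compound and awaits measurement in this assay. Relative to compound 2 it carries bromo in place of iodo on an aromatic carbon, one halogen exchanged for another on the same aromatic carbon.

With every value in the series sitting at the limit, no step beyond the scatter is expected in this assay, and the step that this expectation means is a step that the limit leaves unreadable from compound 2 to compound 4. Compound 4 is estimated at 5 nM, with a range from 1 nM to 20 nM, and this assay is expected most likely to report only its limit once more.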

Compound 4, concentration for 50% growth inhibition: < 10 nM
Compound 4: only a limit was reported; the forecaster's own chance of this, stated with the estimate: 70%; the middle value lies beyond the limit too.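

In this assay compound 4 gives < 10 nM, a limit and not a number. With compound 2 also at a limit, no step can be read from compound 2 to compound 4 for bromo in place of iodo. The compounds shown leave open how far any of them actually differ in growth inhibition, since none has yielded a number.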